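Dog liver microsome stability across the aryl variants

The source may report more compounds than this note shows. Statements on the series, on what has been measured and on what is new or still open speak of the compounds shown alone.

The series shares one core, carried by compound 1 `Nc1nc(NCCNc2ncc(-c3ncc[nH]3)c(-c3ccccc3Br)n2)ccc1[N+](=O)[O-]`, compound 2 `Nc1nc(NCCNc2ncc(-c3ncc[nH]3)c(-c3ccc(F)cc3F)n2)ccc1[N+](=O)[O-]` and compound 3 `Nc1nc(NCCNc2ncc(-c3ncc[nH]3)c(-c3cc(F)ccc3F)n2)ccc1[N+](=O)[O-]`, which differ only in the aryl group on it. In an ADME assay on microsomes from liver (Canis lupus familiaris) for metabolic stability (on this read-out lower numbers stand for a shorter-lived compound and higher numbers for a longer-lived compound), compound 1 gives > 0.5 h, a limit of the assay rather than a number. Compound 2 in this assay likewise gives only the limit > 0.5 h. Compound 3 stands at the same limit in this assay, > 0.5 h. Because every value sits at the limit of > 0.5 h in this assay, at which 3 of the 3 values shown sit, the steps a step that the two limits leave unreadable from compound 1 to compound 2, a step that the two limits leave unreadable from compound 1 to compound 3 and a step that the two limits leave unreadable from compound 2 to compound 3 cannot be sized; the three compounds are indistinguishable on what has been measured, and compound 3 is neither longer- nor shorter-lived than the other two on these numbers.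

Compound 4 `Cc1ccc(-c2nc(NCCNc3ccc([N+](=O)[O-])c(N)n3)ncc2-c2ncc[nH]2)c(Br)c1` is the next variant, differing from compound 3 in one place: 2-bromo-4-methylphenyl in place of 2,5-difluorophenyl on an aromatic carbon. Among the compounds with values here, no measured step bears readably on this change, since each of the three steps is bounded by the same limit. For compound 4 the step in this assay is therefore expected to be unreadable as well, a step that the limit leaves unreadable from compound 3 to compound 4. Compound 4 is estimated to give 1 h in this assay, within a range from 0.4 h to 3 h, and most probably reported once more only as the limit.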

Compound 4, half-life: > 0.5 h
Compound 4 gave a limit, no number; the forecaster's own chance of this, stated with the estimate: 80%; the middle value is on the limit's open side.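

In this assay compound 4 gives > 0.5 h, again a limit and not a number. No step between compound 4 and compound 1, compound 2 or compound 3 can be read, since all four compounds sit at the same limit: the limit of > 0.5 h in this assay, at which 4 of the 4 values shown sit.

On these data alone, how long each of the four compounds actually lasts, and whether the aryl variants differ at all, remains open.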